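This account rests on a few compounds, and the source may have more. Where it says the series, first, only, none or still open, it means among the compounds named here.

In a functional assay on A549 cells (Homo sapiens) for inhibition, read by CCK-8 assay, with a stated time of 48 h (a higher number here means a weaker inhibitor, a lower number a stronger inhibitor), compound 3 `COc1cc(-c2ccnc3cc(-c4c[nH]c5ccccc45)nn23)cc(OC)c1OC` gives 29 nM, the lower of the two numbers obtained so far, and compound 1 `COc1cc(-c2ccnc3cc(-c4cn(CO)c5ccccc45)nn23)cc(OC)c1OC` gives 167 nM. For compound 2 `COc1cc(-c2cc3nccc(-c4c[nH]c5ccccc45)n3n2)cc(OC)c1OC` the assay reports only a limit, > 10000 nM. The change now followed leads to compound 4 `COc1cc(-c2ccnc3cc(-c4ccc(C)cc4)nn23)cc(OC)c1OC`, which carries 4-methylphenyl in place of 1H-indol-3-yl on an aromatic carbon of the five-membered aromatic ring with 2 nitrogen: 4-methylphenyl in place of 1H-indol-3-yl on an aromatic carbon. Within the data shown here, no measured step replaces this whole group. The nearest evidence is a 5.8-fold lower number from compound 1 to compound 3 (0.76 log units; beyond the scatter), a modest step beyond the scatter, where hydrogen takes the place of hydroxymethyl on an aromatic nitrogen of the same 1H-indol-3-yl. Among the measured compounds shown here, since compound 4 loses that group entirely, a step toward a weaker number, and larger than the one seen with compound 1 at 167 nM, seems likely in this assay. The expected change is an estimated 14-fold higher number from compound 3 to compound 4 (1.14 log units; beyond the scatter). For compound 4 the estimated value is 400 nM, within an expected range of 70 nM to 3500 nM.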

Compound 4, half-maximal inhibitory concentration: 3 nM
Beside the measured number, compound 4's estimate is 130-fold (2.12 log units) above it, and the stated range ends above it.
By their numbers in this assay, from the lowest: compound 4; then compound 3; then compound 1. At a limit, above all of these: compound 2.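

In this assay, 4-methylphenyl in place of 1H-indol-3-yl on an aromatic carbon of the five-membered aromatic ring with 2 nitrogen gives a 9.7-fold lower number from compound 3 to compound 4 (0.99 log units; beyond the scatter). The earlier step changed only what sits on the aromatic nitrogen of 1H-indol-3-yl, whereas here the whole group leaves and the number still falls, so a low number at this position does not require that group or its hydrogen-bond donor: a single six-membered aromatic ring of carbon only, with no hydrogen-bond donor, serves in its place. Nothing measured here accounts for the size or direction of this step.

The compounds shown leave open what the methyl itself contributes, and how plain phenyl, 4-methoxyphenyl or a pyridine ring would read at this position. They also leave open how an amine or a carboxylic acid on the phenyl ring would read.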